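Exchanging a Heteroaryl Tail on Weak Jurkat Cell Inhibitors

The source may hold more compounds than are shown below. What is called first, only, known or untested is meant among the compounds shown, and "the series" means these compounds.

compound 1 `COC(=O)c1cc(OCC(=O)[C@H](CC(=O)O)NC(=O)[C@@H](NC(=O)COc2cccc3ccccc23)C(C)C)no1` — 71000 nM
compound 2 `CC(C)[C@H](NC(=O)COc1cccc2ccccc12)C(=O)N[C@@H](CC(=O)O)C(=O)CSc1nnc(-c2ccccc2)o1` — 150000 nM
compound 3 `CC(C)[C@H](NC(=O)COc1cccc2ccccc12)C(=O)N[C@@H](CC(=O)O)C(=O)CSc1nc2ccccc2o1` — a limit only: > 200000 nM

The three measured compounds share one core and differ only in the group attached to a saturated chain carbon bound to a carbonyl carbon. In a functional assay on Jurkat cells (Homo sapiens) for inhibition (on this read-out lower numbers stand for stronger inhibition and higher numbers for weaker inhibition), compound 1 gives 71000 nM. Compound 2 gives 150000 nM, and the change is a 2.1-fold higher number from compound 1 to compound 2 (0.32 log units; beyond the scatter). For compound 3 the assay reports only a limit, > 200000 nM, so no number is known for it. Accordingly an at least 2.8-fold higher number from compound 1 to compound 3 (0.44 log units; beyond the scatter), while an at least 1.3-fold higher number from compound 2 to compound 3 (0.12 log units; that floor lies within the scatter). Compound 3 thus stands at the limit of the assay, with no measured number of its own.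

Compound 4 `CC(C)[C@H](NC(=O)COc1cccc2ccccc12)C(=O)N[C@@H](CC(=O)O)C(=O)COn1nnc2ccccc21` is not yet measured. It differs from compound 3 in a group of 10 heavy atoms (6 carbon, 3 nitrogen, 1 oxygen; one five-membered aromatic ring with 3 hetero atoms, one six-membered aromatic ring of carbon only) in place of a group of 10 heavy atoms (7 carbon, 1 nitrogen, 1 oxygen, 1 sulfur; one five-membered aromatic ring with 2 hetero atoms, one six-membered aromatic ring of carbon only), on a saturated chain carbon bound to a carbonyl carbon. Going by the values given here, the steps that bear on this exchange are the two earlier swaps of one heteroaryl tail for another of similar size: an at least 1.3-fold higher number from compound 2 to compound 3 (0.12 log units; that floor lies within the scatter) and an at least 2.8-fold higher number from compound 1 to compound 3 (0.44 log units; beyond the scatter), both modest. Such exchanges have so far moved the number little, and none made it smaller. In this assay this exchange is therefore expected to give a number no higher from compound 3 to compound 4 (the limit leaves the size open). Because compound 3 already sits at the limit of > 200000 nM in this assay, at which 1 of the 3 values shown sits, compound 4 may again be reported only as a limit. Compound 4 is estimated at 200000 nM, within a range from 60000 nM to 700000 nM.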

Compound 4, half-maximal inhibitory concentration: > 200000 nM
Compound 4: only a limit was reported; the forecaster's own chance of this, stated with the estimate: 60%; the middle value sits exactly at the limit.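

Compound 4 is reported in this assay only as a limit, > 200000 nM, and compound 3 is a limit too, so the step between these two cannot be read. Set against the two compounds with true numbers, the new tail gives an at least 2.8-fold higher number from compound 1 to compound 4 (0.44 log units; beyond the scatter), and it also gives an at least 1.3-fold higher number from compound 2 to compound 4 (0.12 log units; that floor lies within the scatter), so only the first of these gaps is certainly real. Compound 1 therefore remains the strongest of the four, since all of its steps are beyond the scatter, and a further heteroaryl tail on the saturated chain carbon bound to a carbonyl carbon has not lowered the number, while readings that reach the end of the measurable range have become more common in this small set: the limit of > 200000 nM in this assay, at which 2 of the 4 values shown sit.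

The compounds shown leave open how far compound 3 and compound 4 really lie past the limit, and so which of the two is the weaker. They also leave open whether the number would fall with a group of a different kind at this place, such as an amine or a simple methoxy group in place of the heteroaryl tail.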